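Adding a Second Chloro to a Chloroaryl Urea

The source may hold more compounds than are shown below. What is called first, only, known or untested is meant among the compounds shown, and "the series" means these compounds.

Three ureas share one core: compound 1 `Cc1ccccc1NC(=O)N[C@H](C)c1ccccc1`, compound 2 `COc1ccccc1NC(=O)N[C@H](C)c1ccccc1` and compound 3 `C[C@@H](NC(=O)Nc1ccccc1Cl)c1ccccc1`. All three were tested in an ADME assay on the whole organism with Oryza sativa as the target, tested at 10 uM; a lower number here means a stronger effect, a higher number a weaker effect of the compound at the concentration tested. In this assay compound 1 gives 99%, compound 2 gives 96% and compound 3 gives 93%. Compound 3 holds the lowest of the three numbers, yet the gaps to the other two are small: a number 6 percentage points lower from compound 1 to compound 3 (within the scatter) and a number 3 percentage points lower from compound 2 to compound 3 (within the scatter), both within the scatter, as is a number 3 percentage points lower from compound 1 to compound 2 (within the scatter). Exchanging one small group for another on that aromatic carbon has so far left the read-out essentially unchanged.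

Compound 4 `C[C@@H](NC(=O)Nc1cccc(Cl)c1Cl)c1ccccc1` is not yet measured. It differs from compound 3 by chloro in place of hydrogen on an aromatic carbon. For the measured compounds named here, no measured step adds a second chloro to this ring, so the three steps above, all within the scatter, are the only guide, and they describe a different kind of change, an exchange of one group for another rather than the addition of one. On that basis the expected step in this assay is small, a number 1 percentage points lower from compound 3 to compound 4 (within the scatter), with no clear direction beyond the scatter. Compound 4 is therefore estimated at 92%, expected to lie between 84% and 99%.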

Compound 4, a percentage reported as activity, at one concentration (the size of the read-out at that concentration, not a potency): 99%
Estimate against measurement, compound 4: 7 percentage points below; measured number inside the range.
By their numbers in this assay, from the lowest: compounds 3, 2, 1 and 4 (each within the scatter of the next).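

This is the first step shown that adds a group to the ring instead of exchanging one group for another: in this assay, the new chloro brings a number 6 percentage points higher from compound 3 to compound 4 (within the scatter) and so leaves compound 3 and compound 4 indistinguishable in this read-out. The earlier steps shown here showed only that methyl, methoxy and chloro could stand in for one another, whereas this result shows that a chloro can also occupy an aromatic carbon that carried only hydrogen, ortho to a chloro group and meta to a large group, without a shift beyond the scatter. Nothing measured here bears on why the read-out behaves this way.

From the compounds shown here alone, it remains open whether any group at this position would move the read-out beyond the scatter, for example an amine, a carboxylic acid or a longer chain, each quite different from a single chlorine atom. Also open, going by these compounds, is whether a second chloro would behave in the same way on a ring that carries methyl or methoxy in place of the first chloro.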